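Hydroxamic acid series: methylpiperazine addition on two cores

The source may report more compounds than this note shows. Statements on the series, on what has been measured and on what is new or still open speak of the compounds shown alone.

Compound 1 `CN1CCN(c2cccc(C(=O)/C=C/c3cccc(/C=C/C(=O)NO)n3)c2)CC1` and compound 2 `O=C(/C=C/c1cccc(/C=C/C(=O)c2ccccc2)n1)NO` share one core; compound 3 `O=C(/C=C/c1ccc(/C=C/C(=O)c2ccccc2)cn1)NO` and compound 4 `CN1CCN(c2ccc(C(=O)/C=C/c3ccc(/C=C/C(=O)NO)nc3)cc2)CC1` share another. The difference between the two cores is not broken down here. In a functional assay on K562 cells (Homo sapiens) for antiproliferative activity, read by MTT assay, with a stated time of 72 h (on this read-out higher numbers stand for weaker inhibition and lower numbers for stronger inhibition), compound 2 gives 510 nM and compound 1 gives 110 nM; the step of a 4.6-fold lower number from compound 2 to compound 1 (0.67 log units; beyond the scatter) follows from 4-methylpiperazin-1-yl in place of hydrogen on an aromatic carbon. In this assay compound 3 gives 690 nM, within the scatter of compound 2. Compound 4 carries 4-methylpiperazin-1-yl in place of hydrogen on an aromatic carbon, the same kind of change, though the group enters para to a large group rather than meta to a large group. Among the measured compounds shown here, the step expected is a 4.3-fold lower number from compound 3 to compound 4 (0.63 log units; beyond the scatter), resting on the single measured instance a 4.6-fold lower number from compound 2 to compound 1 (0.67 log units; beyond the scatter) and widened for the different place. Compound 4 is therefore estimated at 160 nM, with a range from 60 nM to 450 nM.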

Compound 4, half-maximal inhibitory concentration: 410 nM
Beside the measured number, compound 4's estimate is 2.6-fold (0.41 log units) below it; the range from low to high includes it.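

In this assay the 4-methylpiperazin-1-yl change gives a 1.7-fold lower number from compound 3 to compound 4 (0.23 log units; within the scatter), so the size of the step does not carry over from one core to the other: the same change on two cores in this assay, a 4.6-fold lower number (0.67 log units; beyond the scatter) from compound 2 to compound 1 and a 1.7-fold lower number (0.23 log units; within the scatter) from compound 3 to compound 4, 2.8-fold (0.44 log units) apart, beyond the scatter of two such steps The change lies beyond the scatter only on the core of compound 1, so no general gain from this group can be claimed for the series. With one pair per core, and the group para to a large group only in compound 4, the data do not separate the influence of the core from that of the place.

As far as these compounds go, it remains open whether a morpholin-4-yl or dimethylamino group in the same place would show the same gap between the two cores. Also open, from the compounds shown here alone, is whether a longer chain between the amine and the aromatic ring would change that gap.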